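The source may report more compounds than this note shows. Statements on the series, on what has been measured and on what is new or still open speak of the compounds shown alone.

In an ADME assay on microsomes from liver (Homo sapiens) for metabolic stability (on this read-out lower numbers stand for a shorter-lived compound and higher numbers for a longer-lived compound), compound 2 (`CC(C)C(Cc1ncc[nH]1)c1ccc(-c2ccc3cccc(F)c3c2)[nH]c1=O`) gives 0.106 h, the lowest of three numbers. Compound 3 (`CCC(CC)(c1nnc[nH]1)c1ccc(-c2ccc3cccc(F)c3c2)[nH]c1=O`) gives 1.19 h, and compound 1 (`CCC(CC)(c1nnc[nH]1)c1ccc(-c2ccc3cc(F)cc(F)c3c2)[nH]c1=O`) gives 1.76 h. Compound 4 (`Cc1nc(C(c2ccc(-c3ccc4cccc(F)c4c3)[nH]c2=O)C(C)C)[nH]c1C`) differs from compound 2 in one place: 4,5-dimethyl-1H-imidazol-2-yl in place of (1H-imidazol-2-yl)methyl on a saturated chain carbon bound to an aromatic carbon and a saturated chain carbon. Within the data shown here, only one measured step links two compounds through a single change, a 1.5-fold lower number from compound 1 to compound 3 (0.17 log units; within the scatter), and it lies within the scatter. That step swaps hydrogen for fluoro on an aromatic carbon, so it says nothing direct about this new change. Among the measured compounds shown here, with no measured step of this kind, a large move is not expected in this assay, and the estimated result is a 1.4-fold higher number from compound 2 to compound 4 (0.15 log units; within the scatter), which stays within the scatter. For compound 4, the estimated half-life is 0.15 h, with an expected range from 0.05 h to 0.5 h.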

Compound 4, half-life: 0.268 h
Beside the measured number, compound 4's estimate is 1.8-fold (0.25 log units) below it; low and high end bracket the measured number.
By their numbers in this assay, from the lowest: compound 2; then compound 4; then compounds 3 and 1 (each within the scatter of the next).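

In this assay, putting 4,5-dimethyl-1H-imidazol-2-yl in place of (1H-imidazol-2-yl)methyl on this saturated chain carbon gives a 2.5-fold higher number from compound 2 to compound 4 (0.40 log units; beyond the scatter). The one earlier single change, on an aromatic carbon, gave a 1.5-fold lower number from compound 1 to compound 3 (0.17 log units; within the scatter), so this is the first position shown where one change moves the half-life beyond the scatter. No measurement here explains why the number moves at this position. 

The step changes two things at once, the way the ring is attached and the two added methyl groups, and the compounds shown do not separate them. On these data alone, how an amine or a carboxylic acid on that ring would behave also remains open.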